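This account rests on a few compounds, and the source may have more. Where it says the series, first, only, none or still open, it means among the compounds named here.

Measured compounds:
Compound 1, `O=c1ccoc2cc(OCc3cn(Cc4cccc(F)c4)nn3)ccc12`, gives 7550 nM in a functional assay on HeLa cells (Homo sapiens) for cytotoxicity, read by MTT assay, with a stated time of 48 h; a lower number here means a stronger inhibitor, a higher number a weaker inhibitor.
Compound 2, `O=c1ccoc2cc(OCc3cn(Cc4ccccc4Cl)nn3)ccc12`, reaches only the limit of > 100000 nM in this assay.

Compound 2 stands at the limit of this assay, as the limit of > 100000 nM in this assay, at which 1 of the 2 values shown sits, records; no number is known for it, only that its half-maximal inhibitory concentration lies outside the measured range. Among the measured compounds shown here, the step toward it, an at least 13-fold higher number from compound 1 to compound 2 (1.12 log units; beyond the scatter), is the only measured step and is large; it is the one that bears on the change now considered, since both alter the halogen on the phenyl ring of the benzyl group. Compound 3, `O=c1ccoc2cc(OCc3cn(Cc4ccccc4F)nn3)ccc12`, differs from compound 2 by fluoro in place of chloro on an aromatic carbon. This removes the chloro that compound 2 carries and brings in the halogen that compound 1 carries, though at a different position on the ring. The number for compound 3 is therefore expected to move downward, back toward compound 1, but since the position differs a full return is not assured. Compound 3 is expected to show a step of an at least 3.3-fold lower number from compound 2 to compound 3 (0.52 log units; beyond the scatter). Compound 3 is estimated at 30000 nM, within 6000 nM to 150000 nM.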

Compound 3, half-maximal inhibitory concentration: > 100000 nM
Compound 3: no number, only a limit (the forecaster's own chance of this, stated with the estimate: 40%); at least 3.3-fold (0.52 log units) between middle value and limit.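

In this assay compound 3 also gives only a limit, > 100000 nM, so putting fluoro in place of chloro on this aromatic carbon, ortho to a large group, does not bring a measurable value back into range. The comparison with compound 1 now isolates the position of the halogen: with fluoro kept and only its place changed, 2-fluorophenyl in place of 3-fluorophenyl gives an at least 13-fold higher number from compound 1 to compound 3 (1.12 log units; beyond the scatter), whereas the earlier step changed the halogen and its place together and could not separate the two. The step between compound 2 and compound 3 cannot be read, and these two compounds cannot be ordered, as both stand at the same limit: the limit of > 100000 nM in this assay, at which 2 of the 3 values shown sit.

From the compounds shown here alone, how far the true values of compound 2 and compound 3 lie past that limit remains open, so any difference between chloro and fluoro at this position stays hidden. Going by these compounds, it is also open whether a group of another kind at this place, such as a methoxy group or an amine, would restore a measurable value in this assay, or whether the loss holds for every group there.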